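Ester trimming from compound 1: ethyl to methyl

The source may hold more compounds than are shown below. What is called first, only, known or untested is meant among the compounds shown, and "the series" means these compounds.

In a functional assay on HT-29 cells (Homo sapiens) for cytotoxicity, read by MTT assay, with a stated time of 48 h (on this read-out lower numbers stand for stronger inhibition and higher numbers for weaker inhibition), compound 1 `CCOC(=O)/C=C/c1ccc2c(c1)C(=O)C(=O)N2Cc1ccc(OC)cc1` gives 60 nM, the lower of the two numbers available. Compound 3 `CC(C)(C)OC(=O)/C=C/c1ccc2c(c1)C(=O)C(=O)N2Cc1ccc(Br)cc1` gives 730 nM, a gap from compound 1 that lies beyond the scatter. Compound 2 `COC(=O)/C=C/c1ccc2c(c1)N(Cc1ccc(OC)cc1)C(=O)C2=O` reads > 10000 nM, which is a limit of the assay and not a number. Compound 4 `COC(=O)/C=C/c1ccc2c(c1)C(=O)C(=O)N2Cc1ccc(OC)cc1` follows from compound 1 by hydrogen in place of methyl on a saturated chain carbon bound to an oxygen next to a carbonyl group, or ethoxycarbonyl to methoxycarbonyl. For the measured compounds named here, no measured pair isolates this change, so the anchor is compound 1 at 60 nM, and a small rise in the number in this assay is expected. The estimated change is a 2.0-fold higher number from compound 1 to compound 4 (0.30 log units; within the scatter). Compound 4 is estimated at 120 nM, with an expected range from 30 nM to 700 nM.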

Compound 4, half-maximal inhibitory concentration: 30 nM
Beside the measured number, compound 4's estimate is 4.0-fold (0.60 log units) above it, within the range that was stated.
By their numbers in this assay, from the lowest: compounds 4 and 1 (each within the scatter of the next); then compound 3. At a limit, above all of these: compound 2.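

In this assay, the change from ethoxycarbonyl to methoxycarbonyl now has a measured step: a 2.0-fold lower number from compound 1 to compound 4 (0.30 log units; within the scatter). At this position, shortening ethyl to methyl therefore leaves the number within the scatter. Compound 2 also carries methoxycarbonyl, so this ester alone does not ensure a low number, and its reading is a limit, not a number: the limit of > 10000 nM in this assay, at which 1 of the 4 values shown sits.

Compound 3 differs from compound 1 in more than one place, so it does not isolate the effect of the ester chain. As far as these compounds go, how a carboxylic acid, a primary amide or a propyl ester would read at this position remains open.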